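The source may report more compounds than this note shows. Statements on the series, on what has been measured and on what is new or still open speak of the compounds shown alone.

Measured compounds in a functional assay on MDA-MB-231 cells (Homo sapiens) for inhibition, read by sulforhodamine B assay, with a stated time of 48 h; on this read-out lower numbers stand for stronger inhibition of growth and higher numbers for weaker inhibition of growth:

Compound 1 `O=C(N/N=C\c1ccc(Cl)cc1)C1=C(Cl)c2ccccc2CCC1`: 260 nM
Compound 2 `O=C(N/N=C\c1ccc(F)cc1)C1=C(Cl)c2ccccc2CCC1`: 410 nM
Compound 3 `Cc1cc2c(cc1C)C(Cl)=C(C(=O)N/N=C\c1ccc(Cl)cc1)CCC2`: 410 nM

Compound 1 and compound 2 share one core; the difference between them is fluoro in place of chloro on an aromatic carbon. The step this change made in this assay is a 1.6-fold higher number from compound 1 to compound 2 (0.20 log units; within the scatter), so the two numbers are not distinguishable here. Compound 3 carries a second core; how it differs from the core of compound 1 is not broken down here. In this assay compound 3 gives 410 nM, level with compound 2 at the digits printed, and its gap to compound 1 lies within the scatter as well, so nothing separates the three measured compounds.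

Compound 4 `Cc1cc2c(cc1C)C(Cl)=C(C(=O)N/N=C\c1ccc(F)cc1)CCC2` is not yet measured. It differs from compound 3 by fluoro in place of chloro on an aromatic carbon. Within the data shown here, this is the same change as the one from compound 1 to compound 2, made on the core of compound 3, and the place is the same word for word in both cases. On the one measured occurrence, the change is expected to move compound 4 by about a 1.5-fold higher number from compound 3 to compound 4 (0.17 log units; within the scatter) in this assay, resting on the step of a 1.6-fold higher number from compound 1 to compound 2 (0.20 log units; within the scatter), which was within the scatter. Compound 4 is therefore estimated to give 600 nM in this assay, with an expected range from 300 nM to 1300 nM. No further occurrence of the change is available to check whether its size carries over to the second core.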

Compound 4, concentration for 50% growth inhibition: 840 nM
For compound 4 the middle estimate is 1.4-fold (0.15 log units) below the measured one; measured number inside the range.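

On the core of compound 3, the change from 4-chlorophenyl to 4-fluorophenyl gives a 2.0-fold higher number from compound 3 to compound 4 (0.31 log units; beyond the scatter) in this assay and counts as a modest step. Set beside the same change on the core of compound 1, this step points the same way, and the two sizes cannot be told apart: the same change on two cores in this assay, a 1.6-fold higher number (0.20 log units; within the scatter) from compound 1 to compound 2 and a 2.0-fold higher number (0.31 log units; beyond the scatter) from compound 3 to compound 4, 1.3-fold (0.11 log units) apart, within the scatter of two such steps

Within these two pairs, the step on one core is therefore a fair guide to the step on the other, but this rests on two occurrences, only one of which lies beyond the scatter, so it establishes neither a fixed size for the change nor a rule for the wider series.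

Open, from the compounds shown here alone, is how this position on the phenyl ring responds to groups other than the two halogens, such as methoxy, nitrile, a dimethylamino group or a carboxylic acid, and whether any of them would separate the compounds more clearly than chloro and fluoro do. Also open, going by these compounds, is whether the step from chloro to fluoro keeps its size on a third core, or on any read-out other than this assay.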